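Working notes on compounds 1 to 4: the pentyl-to-bromo step

The source may report more compounds than this note shows. Statements on the series, on what has been measured and on what is new or still open speak of the compounds shown alone.

Measured in a functional assay on the whole organism (strain Zucker) for inhibition, with Rattus norvegicus as the target, with a stated time of 4 h, at a dose of 10 mg/kg by the oral route; a lower number here means less inhibition, a higher number more inhibition at the dose given (going by the name of the read-out):
- compound 1 `CN1CCN(NC(=O)C2=NN(c3ccc(Cl)cc3Cl)C(c3ccc(Cl)cc3)C2)CC1`: 22.6%
- compound 2 `O=C(NN1CCOCC1)C1=NN(c2ccccc2)C(c2ccccc2)C1`: 11.9%
- compound 3 `CCCCCc1ccc(C2CC(C(=O)NN3CCOCC3)=NN2c2ccc(Cl)cc2Cl)cc1`: 13.1%

Compound 3 stands second highest of the three numbers. Its gap to compound 2, the nearest, and its gap to compound 1, the furthest, both lie within the usual scatter, so the three measured compounds cannot be told apart on these numbers.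

Compound 4 `O=C(NN1CCOCC1)C1=NN(c2ccc(Cl)cc2Cl)C(c2ccc(Br)cc2)C1` differs from compound 3 in one place: bromo in place of pentyl on an aromatic carbon. Going by the values given here, no step between measured compounds that differ in a single place is known, and the measured compounds, which differ from one another at several places, all sit within the scatter. The step of a number 1.9 percentage points higher from compound 3 to compound 4 (within the scatter) is therefore expected to be none beyond the scatter. Compound 4 is estimated to give 15% in this assay, within 4% to 28%.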

Compound 4, a percentage reported as inhibition, in the whole organism at one dose (the size of the read-out at that dose, not a potency): 24.2%
Beside the measured number, compound 4's estimate is 9.2 percentage points below it; measured number inside the range.
By their numbers in this assay, from the lowest: compounds 2, 3, 1 and 4 (each within the scatter of the next, the first and the last beyond it).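

In this assay, going by these compounds alone, the change from 4-pentylphenyl to 4-bromophenyl gives a number 11.1 percentage points higher from compound 3 to compound 4 (beyond the scatter) and so provides the first readable single-place step. Within the data shown here, it shows that this aromatic carbon, para to a large group, can respond beyond the scatter to one substituent change, which the earlier compounds, differing at several places, could not show. No measurement at hand accounts for this step.

Going by these compounds, whether the rise follows from the entry of bromo or from the loss of pentyl remains open. This single step also cannot indicate how a methoxy group, an amine or a carboxylic acid would read at this position.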